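A few compounds are considered here, and "the series" means these few. Any claim that something is new, unique, unknown or untested is made for them only; others in the source may bear on it.

Measured compounds in a functional assay on CHO-K1 cells for antagonist activity at transient receptor potential cation channel subfamily V member 1 (Homo sapiens), read by FLIPR; on this read-out lower numbers stand for stronger inhibition and higher numbers for weaker inhibition:
- Compound 1 `CC(C(=O)NCc1ccc(C(F)(F)F)nc1)c1ccc(NS(C)(=O)=O)c(F)c1`: "not active" (no number reported)
- Compound 2 `CC1CCC(Nc2nc(C(F)(F)F)ccc2CNC(=O)C(C)c2ccc(NS(C)(=O)=O)c(F)c2)CC1`: 1130 nM
- Compound 3 `CC(C(=O)NCc1ccc(C(F)(F)F)nc1NCc1ccccc1)c1ccc(NS(C)(=O)=O)c(F)c1`: 203 nM

Compound 1, which carries no substituent on the ring nitrogen, gives no number in this assay. Among the measured compounds shown here, compound 2 and compound 3 both carry a substituent on a nitrogen on the aromatic ring, and compound 3 stands with the lowest of the two numbers; the only counted step in the set is a 5.6-fold lower number from compound 2 to compound 3 (0.75 log units; beyond the scatter), which leaves compound 3 as the better of the two measured entries.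

Compound 4 `CC(C(=O)NCc1ccc(C(F)(F)F)nc1NCc1cccnc1)c1ccc(NS(C)(=O)=O)c(F)c1` keeps everything of compound 3 apart from one change: pyridin-3-yl in place of phenyl on a saturated chain carbon bound to a nitrogen on an aromatic ring. For the measured compounds named here, no measured step covers this kind of exchange. The step from compound 2 to compound 3 concerns the group on the same ring nitrogen but swaps a saturated ring for an aromatic one, a larger change than the one at hand, so it gives only a loose frame: the region accepts different groups, and a ring-for-ring exchange of matched size is unlikely to move the number as far. Compound 4 is therefore expected to stay close to compound 3, the step of a 1.2-fold higher number from compound 3 to compound 4 (0.09 log units; within the scatter) read as within the scatter. The estimate for compound 4 is 250 nM, with a range from 80 nM to 800 nM.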

Compound 4, half-maximal inhibitory concentration: "not active" (no number reported)
Compound 4 has no reported number here; the estimate stays without a comparison.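

In this assay, among the compounds shown here, compound 4 gives "not active" (no number reported) and so no step from compound 3 to compound 4 can be read. No measured property shown here bears on this result. The compounds shown leave open whether any other group on the ring nitrogen gives a lower number than compound 3 at 203 nM in this series.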